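Working notes: aryl change from compound 2 to compound 3

The source may hold more compounds than are shown below. What is called first, only, known or untested is meant among the compounds shown, and "the series" means these compounds.

In a functional assay on HCT-116 cells (Homo sapiens) for antiproliferative activity, read by sulforhodamine B assay, with a stated time of 48 h (on this read-out higher numbers stand for weaker inhibition and lower numbers for stronger inhibition), compound 2 `COc1cc(OC)c(C(=O)/C=C/c2ccc(Br)cc2)c(OCC=C(C)C)c1` gives 2100 nM, and compound 1 `COc1cc(OC)c(C(=O)/C=C/c2ccc(F)cc2)c(OCC=C(C)C)c1` gives 3200 nM, so the two lie within the scatter of each other. Compound 3 `COc1cccc(/C=C/C(=O)c2c(OC)cc(OC)cc2OCC=C(C)C)c1` carries 3-methoxyphenyl in place of 4-bromophenyl on a double-bonded chain carbon bound to a double-bonded chain carbon. Among the measured compounds shown here, the only measured step, a 1.5-fold lower number from compound 1 to compound 2 (0.18 log units; within the scatter), is bromo in place of fluoro and stays within the scatter. For the measured compounds named here, no measured step tests a 3-methoxyphenyl group, so no shift beyond the scatter is expected in this assay. The expected change is a 1.2-fold higher number from compound 2 to compound 3 (0.08 log units; within the scatter). Compound 3 is estimated at 2500 nM, with an expected range of 900 nM to 7000 nM.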

Compound 3, half-maximal inhibitory concentration: 7700 nM
Beside the measured number, compound 3's estimate is 3.1-fold (0.49 log units) below it; the measured number lies above the stated range.
By their numbers in this assay, from the lowest: compounds 2 and 1 (each within the scatter of the next); then compound 3.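

In this assay the aryl group on this double-bonded chain carbon turns out to be a place where the number can move beyond the scatter: 3-methoxyphenyl in place of 4-bromophenyl gives a 3.7-fold higher number from compound 2 to compound 3 (0.56 log units; beyond the scatter) and in place of 4-fluorophenyl gives a 2.4-fold higher number from compound 1 to compound 3 (0.38 log units; beyond the scatter) with weaker inhibition in both. The bromo and fluoro compounds gave no such separation. No evidence at hand bears on the reason for this shift.

Still open, on these data alone, is whether the step follows the methoxy group itself or its place on the ring, a question that 4-methoxyphenyl and 3-bromophenyl would separate. As far as these compounds go, how an amine on this aryl ring would read is also open.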